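Replacing the amine substituent of compound 3

The source may hold more compounds than are shown below. What is called first, only, known or untested is meant among the compounds shown, and "the series" means these compounds.

In a functional assay on MCF7 cells (Homo sapiens) for antiproliferative activity (a lower number here means a stronger inhibitor, a higher number a weaker inhibitor), three compounds that differ only in the group on an amine nitrogen have been measured: compound 1 (`CC(C)=CCc1cc(C(=O)Nc2cc3ccc(OCCCNC(C)C)c(C)c3oc2=O)ccc1O`) gives 740 nM, compound 2 (`CC(C)=CCc1cc(C(=O)Nc2cc3ccc(OCCCNCCO)c(C)c3oc2=O)ccc1O`) gives 1560 nM and compound 3 (`CC(C)=CCc1cc(C(=O)Nc2cc3ccc(OCCCN[C@H](C)c4ccccc4)c(C)c3oc2=O)ccc1O`) gives 1450 nM. Compound 3 lies within the scatter of both others, as shown by a 2.0-fold higher number from compound 1 to compound 3 (0.29 log units; within the scatter) and a 1.1-fold lower number from compound 2 to compound 3 (0.03 log units; within the scatter). Going by the values given here, the only step beyond the scatter is modest: a 2.1-fold higher number from compound 1 to compound 2 (0.32 log units; beyond the scatter). Compound 4 (`CC(C)=CCc1cc(C(=O)Nc2cc3ccc(OCCCN[C@@H]4C[C@H]5CC[C@@H]4C5)c(C)c3oc2=O)ccc1O`) differs from compound 3 by a group of 7 heavy atoms (7 carbon; 2 five-membered non-aromatic rings of carbon only) in place of a group of 8 heavy atoms (8 carbon; one six-membered aromatic ring of carbon only), on an amine nitrogen. These three steps are all small, so only a small move is expected here, with no clear direction. The estimated change is a 1.3-fold lower number from compound 3 to compound 4 (0.12 log units; within the scatter), which would stay within the scatter. Compound 4 is expected at 1100 nM, with an estimated range of 500 nM to 2400 nM.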

Compound 4, half-maximal inhibitory concentration: 1030 nM
The estimate for compound 4 lay 1.1-fold (0.03 log units) above the measured number, within the range that was stated.
By their numbers in this assay, from the lowest: compounds 1, 4, 3 and 2 (each within the scatter of the next, the first and the last beyond it).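

Notes on the amine nitrogen: in this assay, the group with 2 five-membered non-aromatic rings of carbon only reads the same as the 1-phenylethyl group within the scatter (a 1.4-fold lower number from compound 3 to compound 4 (0.15 log units; within the scatter)), so an aromatic ring is not needed here for a number in this range. Compound 4 also stays within the scatter of the 2-hydroxyethyl compound (a 1.5-fold lower number from compound 2 to compound 4 (0.18 log units; within the scatter)) and the isopropyl compound (a 1.4-fold higher number from compound 1 to compound 4 (0.14 log units; within the scatter)), so it cannot be placed in any order against the other three. Nothing available bears on why these groups read alike.

Open, as far as these compounds go, is whether a carboxylic acid on a longer chain, or a second amine, on this nitrogen would move the number beyond the scatter.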